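The compounds below may be only part of what the source reports. "The series", "measured", "known", "first", "only" and "open" are said of these compounds alone.

Measured compounds, with their results in a functional assay on SK-MEL-2 cells (Homo sapiens) for cytotoxicity, read by sulforhodamine B assay, with a stated time of 48 h; a lower number here means a stronger inhibitor of growth, a higher number a weaker inhibitor of growth:

Compound 1 `ClCc1ccc(Cn2cnc3c(Cl)ncnc32)cc1` gives > 100000 nM, which is a limit of the measurement rather than a number.
Compound 2 `ClCc1ccccc1Cn1cnc2ncnc(Cl)c21` gives 19500 nM.
Compound 3 `ClCc1ccc(Cn2cnc3c(Cl)nc(Cl)nc32)cc1` gives 43700 nM.

All three share a purine-type core carrying a benzyl group with a chloromethyl substituent; the difference between the core of compound 1 and the core of compound 2 is not broken down here. Compound 3 differs from compound 1 by chloro in place of hydrogen on an aromatic carbon. That change produced an at least 2.2-fold lower number from compound 1 to compound 3 (0.35 log units; beyond the scatter), though because compound 1 sits at the limit of > 100000 nM in this assay, at which 1 of the 3 values shown sits, the true size of that step is not known and may be larger than the figure stated. Compound 2 shows the lowest of the two numbers reported, and the step from compound 3 to compound 2 is beyond the scatter.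

Compound 4 `ClCc1ccccc1Cn1cnc2nc(Cl)nc(Cl)c21` has not yet been measured in this assay. It differs from compound 2 by chloro in place of hydrogen on an aromatic carbon, the same change, at the same kind of place, that turned compound 1 into compound 3. The expectation for compound 4 therefore rests on the step that compound 1 made to compound 3, an at least 2.2-fold lower number from compound 1 to compound 3 (0.35 log units; beyond the scatter), applied to the value of compound 2, 19500 nM. An estimated step of a 2.2-fold lower number from compound 2 to compound 4 (0.34 log units; beyond the scatter) is expected from compound 2 to compound 4. Compound 4 is thus estimated to give about 9000 nM, with a plausible range from 3000 nM to 25000 nM.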

Compound 4, concentration for total growth inhibition: 5750 nM
Beside the measured number, compound 4's estimate is 1.6-fold (0.19 log units) above it; low and high end bracket the measured number.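

In this assay, chloro in place of hydrogen on an aromatic carbon, here between two ring nitrogen atoms, gave a 3.4-fold lower number from compound 2 to compound 4 (0.53 log units; beyond the scatter), so the change that lowered the number on the core of compound 1 also lowered it on the core of compound 2. Across these two pairs, the direction of the change carried over from one core to the other: the same change on two cores in this assay, an at least 2.2-fold lower number (0.35 log units; beyond the scatter) from compound 1 to compound 3 and a 3.4-fold lower number (0.53 log units; beyond the scatter) from compound 2 to compound 4; the limit leaves it open whether they differ What this does not show is whether the size of the step carries over as well, since the first pair rests on a limit of the assay and not on a number: the limit of > 100000 nM in this assay, at which 1 of the 4 values shown sits.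

The compounds shown leave open whether a different group on that same aromatic carbon, such as fluoro, methoxy or an amine, would move the number in the same direction as chloro. They also leave open how the number would respond on either core if the chloromethyl group gave way to a methyl or a hydroxymethyl group, and whether the same step would appear in any other cell line.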